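Chloro in Place of Acetoxy on Two Related Cores

The source may hold more compounds than are shown below. What is called first, only, known or untested is meant among the compounds shown, and "the series" means these compounds.

Measured compounds:
compound 1 `CC(=O)OCCc1c(C)nc(Cl)nc1Cl` gives > 100000 nM, a limit of the assay
compound 2 `COc1nc(C)c(CCOC(C)=O)c(OC)n1` gives 47000 nM
compound 3 `Cc1nc(Cl)nc(Cl)c1CCCl` gives 3000 nM

All three numbers come from a functional assay on NCI-H460 cells (Homo sapiens) for antiproliferative activity, read by MTT assay, with a stated time of 24 h; a higher number here means a weaker inhibitor, a lower number a stronger inhibitor. Compound 1 reaches only a limit in this assay, no number. Compound 3 differs from compound 1 in one place, (chloro in place of acetoxy on a saturated chain carbon, two bonds along the chain from an aromatic carbon), and this change made an at least 33-fold lower number from compound 1 to compound 3 (1.52 log units; beyond the scatter). How large the step really is cannot be told exactly, since compound 1 sits at the limit of > 100000 nM in this assay, at which 1 of the 3 values shown sits.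

Compound 2 carries a different core from compound 1; the difference between the two cores is not broken down here. Compound 2 has the highest number of the two measured values, and the nearest measured compound is compound 3, which gives a lower number.

Compound 4 `COc1nc(C)c(CCCl)c(OC)n1` has not yet been measured in this assay. It differs from compound 2 by chloro in place of acetoxy on a saturated chain carbon, two bonds along the chain from an aromatic carbon, the same change that separates compound 1 from compound 3, with the place described in the same words. For compound 4 the author expects a step of about a 24-fold lower number from compound 2 to compound 4 (1.37 log units; beyond the scatter) from compound 2 in this assay, resting on the step from compound 1 to compound 3 of an at least 33-fold lower number from compound 1 to compound 3 (1.52 log units; beyond the scatter) and on the measured value of compound 2 of 47000 nM. Compound 4 is therefore estimated at 2000 nM, with a likely range from 400 nM to 10000 nM.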

Compound 4, half-maximal inhibitory concentration: > 100000 nM
Compound 4: only a limit was reported (the forecaster's own chance of this, stated with the estimate: 5%); middle value at least 50-fold (1.69 log units) away from the limit.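

In this assay compound 4 gives > 100000 nM, which is a limit of the assay and not a number. On the core of compound 2, chloro in place of acetoxy gave an at least 2.1-fold higher number from compound 2 to compound 4 (0.32 log units; beyond the scatter), so the change did not carry over from the core of compound 1, where the number moved the other way: the same change on two cores in this assay, an at least 33-fold lower number (1.52 log units; beyond the scatter) from compound 1 to compound 3 and an at least 2.1-fold higher number (0.32 log units; beyond the scatter) from compound 2 to compound 4, at least 70-fold (1.85 log units) apart, beyond the scatter of two such steps This shows that, in this series, the result of the change depends on the core it is made on, but it does not give the true size of either step, and with only one pair on each core it offers neither a rule for other cores nor a reason for the reversal, with compound 1 and compound 4 both reported only as limits: the limit of > 100000 nM in this assay, at which 2 of the 4 values shown sit.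

The compounds shown leave open which difference between the two cores matters, and a core carrying one chloro and one methoxy would speak to that. From the compounds shown here alone, it also remains open whether a hydroxy group or an amine in place of the acetoxy, or a longer chain ending in chloro, would follow the pair on the core of compound 1 or the pair on the core of compound 2.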